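Hydroxy in place of methoxy on the bis(trifluoromethyl) urea

The source may hold more compounds than are shown below. What is called first, only, known or untested is meant among the compounds shown, and "the series" means these compounds.

In a functional assay on UACC-257 cells (Homo sapiens) for inhibition, read by sulforhodamine B assay, with a stated time of 48 h (on this read-out lower numbers stand for higher toxicity in this test and higher numbers for lower toxicity in this test), compound 2 `COc1cc(-c2nn(-c3cccc(NC(=O)Nc4cc(C(F)(F)F)cc(C(F)(F)F)c4)c3)cc2-c2ccncc2)ccc1Cl` gives 26200 nM, the highest of the two numbers in this set, with compound 3 `COc1cc(-c2nn(-c3cccc(NC(=O)Nc4cccc(C(F)(F)F)c4)c3)cc2-c2ccncc2)ccc1Cl` nearest at 7580 nM. Compound 1 `O=C(Nc1cccc(-n2cc(-c3ccncc3)c(-c3ccc(Cl)c(O)c3)n2)c1)Nc1cccc(C(F)(F)F)c1` reaches only a limit of this assay, > 32500 nM. The change from compound 2 to compound 4 `O=C(Nc1cccc(-n2cc(-c3ccncc3)c(-c3ccc(Cl)c(O)c3)n2)c1)Nc1cc(C(F)(F)F)cc(C(F)(F)F)c1` is hydrogen in place of methyl on an oxygen on an aromatic ring, read one bond further out as methoxy to hydroxy. The same exchange run the other way is the step of an at least 4.2-fold lower number from compound 1 to compound 3 (0.63 log units; beyond the scatter), but compound 1 sits at the limit of > 32500 nM in this assay, at which 1 of the 3 values shown sits, so the true size is not known. The other measured step, a 3.5-fold lower number from compound 2 to compound 3 (0.54 log units; beyond the scatter), concerns a trifluoromethyl group and does not bear on this change. On this basis the number is expected to rise by a 4.2-fold higher number from compound 2 to compound 4 (0.62 log units; beyond the scatter). Because compound 1 stands at the limit of > 32500 nM in this assay, at which 1 of the 3 values shown sits, a limit rather than a number is the likely outcome for compound 4. Compound 4 is estimated at 110000 nM, within 32500 nM to 350000 nM.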

Compound 4, concentration lethal to 50% of the cells: 10600 nM
The estimate for compound 4 lay 10-fold (1.02 log units) above the measured number; measured number below the stated range.
By their numbers in this assay, from the lowest: compounds 3 and 4 (each within the scatter of the next); then compound 2. At a limit, above all of these: compound 1.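

In this assay, methoxy to hydroxy on the 4-chloro-3-methoxyphenyl group gives a 2.5-fold lower number from compound 2 to compound 4 (0.39 log units; beyond the scatter), so this exchange does not run in one direction across the two cores: the same change on two cores in this assay, an at least 4.2-fold lower number (0.63 log units; beyond the scatter) from compound 1 to compound 3 and a 2.5-fold higher number (0.39 log units; beyond the scatter) from compound 4 to compound 2, at least 10-fold (1.02 log units) apart, beyond the scatter of two such steps. The added trifluoromethyl reverses in the same way once hydroxy replaces methoxy, giving an at least 3.0-fold lower number from compound 1 to compound 4 (0.48 log units; beyond the scatter): the same change on two cores in this assay, a 3.5-fold lower number (0.54 log units; beyond the scatter) from compound 2 to compound 3 and an at least 3.0-fold higher number (0.48 log units; beyond the scatter) from compound 4 to compound 1, at least 10-fold (1.02 log units) apart, beyond the scatter of two such steps. In these four compounds, the effects of the two changes therefore do not add independently, and each depends on the group present at the other place.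

As far as these compounds go, compound 1 gives only a limit, > 32500 nM, so the true size of the steps involving it remains unknown. From the compounds shown here alone, whether the reversal extends to ethoxy, a longer chain on the oxygen, or an amine in place of the hydroxy remains open.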